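The source may hold more compounds than are shown below. What is called first, only, known or untested is meant among the compounds shown, and "the series" means these compounds.

Measured compounds in this series:

compound 1 `CC(C)n1cc(C(=O)C(=O)Nc2ccc(C(F)(F)F)nc2)c2ccccc21` — > 10000 nM
compound 2 `COCCn1cc(C(=O)C(=O)Nc2ccc(C(F)(F)F)nc2)c2ccccc21` — > 10000 nM

In a functional assay on FaDu cells (Homo sapiens) for cytotoxicity, read by MTT assay, with a stated time of 72 h (a higher number here means that more compound is tolerated, a lower number that less compound is tolerated), compound 1 gives > 10000 nM, which is a limit of the assay and not a number. Compound 2 gives > 10000 nM in this assay, again a limit rather than a number. Within the data shown here, compound 2 therefore stands only at a limit, and the sole measured step, a step that the two limits leave unreadable from compound 1 to compound 2, cannot be read in size or direction, because both of its values sit at the limit of > 10000 nM in this assay, at which 2 of the 2 values shown sit.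

Compound 3 `COCCn1cc(C(=O)C(=O)Nc2ccc(OC(C)(C)C)nc2)c2ccccc21` differs from compound 2 by tert-butoxy in place of trifluoromethyl on an aromatic carbon. Among the measured compounds shown here, no measured step touches this aromatic carbon: the one step on record concerns the aromatic nitrogen and is itself unreadable. There is thus nothing in the numbers shown from which a step beyond the scatter, in either direction, can be expected in this assay. With both measured values at the same limit, compound 3 is expected to sit there as well, so the estimate for the step is a step that the limit leaves unreadable from compound 2 to compound 3, with only the possibility that a number below the limit appears. The expected value for compound 3 in this assay is 15000 nM, between 5000 nM and 50000 nM.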

Compound 3, concentration lethal to 50% of the cells: 858 nM
Compound 3: middle estimate off by 17-fold (1.24 log units), on the high side, and the stated range ends above it.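

Among these compounds, the substituent on the aromatic carbon next to the ring nitrogen is the first place where this assay gives a readable response: tert-butoxy in place of trifluoromethyl gives an at least 11-fold lower number from compound 2 to compound 3 (1.06 log units; beyond the scatter). Compound 2 gives > 10000 nM, which is a limit of the assay and not a number, so the true size of this step may be greater than the printed one. Compound 3 is the only compound shown that carries a number, and the other values stay at the assay's limit: the limit of > 10000 nM in this assay, at which 2 of the 3 values shown sit.

Going by these compounds, the step from isopropyl to 2-methoxyethyl on the aromatic nitrogen cannot be read, so it remains open whether that substituent changes the outcome in a compound that gives a number, as it would with isopropyl paired with tert-butoxy. On these data alone, with only one replacement at the aromatic carbon, it also remains open whether the lower number belongs to tert-butoxy alone or extends to other groups there, such as methoxy, a longer alkoxy chain or an amine.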